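Three triazole thioethers that stayed inactive on lung cancer cells

The source may report more compounds than this note shows. Statements on the series, on what has been measured and on what is new or still open speak of the compounds shown alone.

Measured so far:
- compound 1 `Cc1nnc(SCC(=O)c2ccc(Cl)cc2)n1N1C(=O)c2ccccc2C1=O`: > 200000 nM, a limit of the assay rather than a number
- compound 2 `Cc1ccc(C(=O)CSc2nnc(C)n2N2C(=O)c3ccccc3C2=O)cc1`: > 200000 nM, likewise a limit
- compound 3 `CCCc1nnc(SCC(=O)c2ccc(Cl)cc2)n1N1C(=O)c2ccccc2C1=O`: > 200000 nM, likewise a limit

All three were tested in a functional assay on A549 cells (Homo sapiens) for cytotoxicity, read by MTT assay, with a stated time of 48 h; on this read-out lower numbers stand for stronger inhibition and higher numbers for weaker inhibition. Each value is a limit of the assay, so none of the three shows measurable cytotoxicity here; the limit of > 200000 nM in this assay, at which 3 of the 3 values shown sit, sums this up.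

Compound 2 differs from compound 1 by methyl in place of chloro on an aromatic carbon. The step that the two limits leave unreadable from compound 1 to compound 2 cannot be sized, since both ends are limits. Compound 3 differs from compound 1 by ethyl in place of hydrogen on a saturated chain carbon bound to an aromatic carbon, and again a step that the two limits leave unreadable from compound 1 to compound 3 cannot be sized for the same reason.

Compound 4 `CCCc1nnc(SCC(=O)c2ccc(C)cc2)n1N1C(=O)c2ccccc2C1=O` is not yet measured. It differs from compound 3 by methyl in place of chloro on an aromatic carbon, the same change that was made from compound 1 to compound 2, at a place described in the same words.

Compound 4 is expected to stay at the limit, because compound 3 gives > 200000 nM and because the limit of > 200000 nM in this assay, at which 3 of the 3 values shown sit, shows every related compound at that same limit. The expected step that the limit leaves unreadable from compound 3 to compound 4 is therefore estimated as essentially none, and compound 4 is estimated at 300000 nM, within 150000 nM to 1000000 nM.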

Compound 4, half-maximal inhibitory concentration: > 200000 nM
Compound 4: only a limit was reported (the forecaster's own chance of this, stated with the estimate: 85%); the middle value lies beyond the limit too.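

Compound 4 gives > 200000 nM as a limit of the assay and not a number. Its steps from compound 3 and from compound 2 cannot be read. The compounds shown leave open how far either change moves cytotoxicity in this assay and whether any close relative reaches a measurable value. All four stand together: the limit of > 200000 nM in this assay, at which 4 of the 4 values shown sit.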